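The source may report more compounds than this note shows. Statements on the series, on what has been measured and on what is new or still open speak of the compounds shown alone.

Working notes on the series.

Three compounds of the shared core have numbers in a functional assay on HepG2 cells (Homo sapiens) for antiproliferative activity, tested at 1 uM; a higher number here means more inhibition at the concentration tested (going by the name of the read-out), a lower number less inhibition. Compound 1 `Cc1nn(-c2ccccc2)c(Oc2ccc(Cl)cc2)c1/C=N/OCc1ccc(C(=O)OC(C)(C)C)cc1` gives -31.1%, the lowest of the three numbers. Compound 3 `Cc1nn(C)c(Oc2ccccc2)c1/C=N/OCc1ccc([N+](=O)[O-])cc1` gives -2.8%, the nearest to compound 1 and above it beyond the usual scatter. Compound 2 `Cc1nn(C)c(Oc2ccc(Cl)cc2)c1/C=N/OCc1ccc(C(F)(F)F)cc1` gives 20.6%, the furthest from compound 1, again beyond the scatter. No pair among these three differs in one place only, so none of these gaps can be read as a single-change step.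

Compound 4 `CCOC(=O)c1ccc(CO/N=C/c2c(C)nn(-c3ccccc3)c2Oc2ccc(Cl)cc2)cc1` is not yet measured in this assay. It differs from compound 1 in one place: ethyl in place of tert-butyl on an oxygen next to a carbonyl group. The change is small in count and keeps the rest of the molecule, including the carbonyl and the ring it sits on, as in compound 1. Nothing measured here bears on this exact change, so the direction of the step is open; the expectation is a step within the scatter, or not far beyond it, in either direction, from compound 1, which gives -31.1% in this assay.

The estimate for compound 4 in this assay is -15%, with a range from -45% to 20%. This estimate means a step of a number 16.1 percentage points higher from compound 1 to compound 4 (beyond the scatter).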

Compound 4, a percentage reported as inhibition, at one concentration (the size of the read-out at that concentration, not a potency): -31.8%
Compound 4: the middle estimate sits 16.8 percentage points above what was measured; low and high end bracket the measured number.
By their numbers in this assay, from the lowest: compounds 4 and 1 (each within the scatter of the next); then compound 3; then compound 2.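

In this assay, for the compounds shown here, ethyl in place of tert-butyl on an oxygen next to a carbonyl group gives a number 0.7 percentage points lower from compound 1 to compound 4 (within the scatter), the first single-change step. At this position, tert-butyl and ethyl therefore cannot be told apart in this read-out at the concentration tested, on the core of compound 1. Nothing available bears on why the two groups read alike.

As far as these compounds go, whether a carboxylic acid or an amide in place of this ester-bearing carbonyl group, or a longer chain on the same oxygen, would give a number beyond the scatter from compound 1 stays open. This single pair also leaves open whether the same exchange reads alike on the other compounds of the shared core.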